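Trimming the Hydroxylated Chain of Compound 2

The compounds below may be only part of what the source reports. "The series", "measured", "known", "first", "only" and "open" are said of these compounds alone.

Of the compounds shown here, two with a shared core have numbers so far in a functional assay on K562 cells (Homo sapiens) for antiproliferative activity; a higher number here means a weaker inhibitor of growth, a lower number a stronger inhibitor of growth. Compound 1 (`COC(=O)CCCCCCCCCCCCCC/C=C1\CC(CO)(COC(=O)C(C)(C)C)OC1=O`) gives 0.856 ug/mL, and compound 2 (`CCCCCCCCC(O)CCCCCC/C=C1\CC(CO)(COC(=O)C(C)(C)C)OC1=O`) gives 7.3 ug/mL. Compound 2 therefore stands as the higher number of the two and the weaker inhibitor of growth, with a gap beyond the scatter. For the measured compounds named here, these two compounds differ in their chains, and no pair measured so far differs in one place only.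

Compound 3 (`CC(C)(C)C(=O)OCC1(CO)C/C(=C\CCCCCCCCCCCO)C(=O)O1`) departs from compound 2 at a single place: 5-hydroxypentyl in place of 1-hydroxynonyl on a saturated chain carbon, six bonds along the chain from a double-bonded chain carbon. This puts 5-hydroxypentyl in place of 1-hydroxynonyl on a saturated chain carbon, six bonds along the chain from a double-bonded chain carbon. Going by the values given here, no measured pair shows what such a change does in this assay, so no step beyond the scatter is expected in either direction, and the range must stay wide. The expectation rests on compound 2 at 7.3 ug/mL. The expected change is a 1.1-fold higher number from compound 2 to compound 3 (0.04 log units; within the scatter). For compound 3 the estimated value is 8 ug/mL, with an expected range from 2.5 ug/mL to 25 ug/mL.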

Compound 3, concentration for 50% growth inhibition: 1.09 ug/mL
Beside the measured number, compound 3's estimate is 7.3-fold (0.87 log units) above it; the whole stated range lies above it.
By their numbers in this assay, from the lowest: compounds 1 and 3 (each within the scatter of the next); then compound 2.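

In this assay, for the compounds shown here, the saturated chain carbon six bonds along the chain from a double-bonded chain carbon proves sensitive to the group it carries: 5-hydroxypentyl in place of 1-hydroxynonyl gives a 6.7-fold lower number from compound 2 to compound 3 (0.83 log units; beyond the scatter) as the first single-place step, and it lies beyond the scatter. Both groups carry a hydroxy, so a hydroxy in the chain does not by itself fix the number in this assay. Hydroxy in place of 3-(methoxycarbonyl)propyl on a saturated chain carbon gives a 1.3-fold higher number from compound 1 to compound 3 (0.10 log units; within the scatter) and stays within the scatter, so this assay does not separate those two chain forms.

On these data alone, how an amine or a carboxylic acid in place of that hydroxy would fare remains open, as does the outcome for a longer chain. The compounds shown cannot separate chain length from where the hydroxy sits, and nothing available accounts for the step from compound 2 to compound 3.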